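This account rests on a few compounds, and the source may have more. Where it says the series, first, only, none or still open, it means among the compounds named here.

Compound 1 `COc1nc(C2=NOCC(c3ccc(Cl)cc3)N2)ccc1-n1cnc(C)c1` gives 2 mL/min/kg in an ADME assay on cells (Hepatocyte, Homo sapiens) for pharmacokinetics; on this read-out lower numbers stand for slow clearance and higher numbers for fast clearance.
Compound 2 `COc1nc(C2=NOCC(c3ccc(C4CC4)cc3)N2)ccc1-n1cnc(C)c1` gives 208 mL/min/kg in this assay.
Compound 3 `COc1nc(C2=NOCC(c3ccc(C(C)(C)C)cc3)N2)ccc1-n1cnc(C)c1` gives 320 mL/min/kg in this assay.

Compound 1 stands lowest of the three measured numbers in this assay: the nearest number lies a 100-fold higher number from compound 1 to compound 2 (2.02 log units; beyond the scatter), the furthest a 160-fold higher number from compound 1 to compound 3 (2.20 log units; beyond the scatter), while between the two larger groups the step is only a 1.5-fold higher number from compound 2 to compound 3 (0.19 log units; within the scatter). Compound 4 `COc1nc(C2=NOCC(c3ccc(Cl)c(C)c3)N2)ccc1-n1cnc(C)c1` differs from compound 1 by methyl in place of hydrogen on an aromatic carbon. Among the measured compounds shown here, no measured step matches this change directly; the two large steps bear on it only loosely, as both remove the chloro group that compound 4 keeps. A rise is therefore expected, but a modest one, well short of the step of a 100-fold higher number from compound 1 to compound 2 (2.02 log units; beyond the scatter). Compound 4 is expected to give 6 mL/min/kg, within a range of 2 mL/min/kg to 20 mL/min/kg, which means an estimated step of a 3.0-fold higher number from compound 1 to compound 4 (0.48 log units; beyond the scatter).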

Compound 4, clearance: 70 mL/min/kg
Compound 4: middle estimate off by 12-fold (1.07 log units), on the low side; measured number above the stated range.
By their numbers in this assay, from the lowest: compound 1; then compound 4; then compounds 2 and 3 (each within the scatter of the next).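

In this assay, the chloro group alone does not secure a low number: a methyl on the aromatic carbon ortho to it gives a 35-fold higher number from compound 1 to compound 4 (1.54 log units; beyond the scatter). This single added methyl thus moves the number most of the way towards those of the compounds without chloro, although a 4.6-fold lower number from compound 3 to compound 4 (0.66 log units; beyond the scatter) and a 3.0-fold lower number from compound 2 to compound 4 (0.47 log units; beyond the scatter) still separate them from the methyl compound. Nothing available here explains the rise. Going by these compounds, whether a fluoro or a methoxy group on the same carbon would raise the number as far remains open. So does whether a methyl elsewhere on this ring would have the same effect.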